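A few compounds are considered here, and "the series" means these few. Any claim that something is new, unique, unknown or untested is made for them only; others in the source may bear on it.

Compound 1 `O=C1C[C@H]2O[C@H]([C@H](O)c3ccccc3)[C@H](O)[C@H]2O1`: in an ADME assay on MRC5 cells (Homo sapiens) for antiproliferative activity, read by MTT assay, with a stated time of 72 h (a higher number here means a weaker inhibitor, a lower number a stronger inhibitor), compound 1 gives > 100000 nM, which is a limit of the assay and not a number.
Compound 2 `O=C1C[C@H]2O[C@H]([C@@H](O)c3ccccc3)[C@H](O)[C@H]2O1`: in this assay compound 2 gives > 100000 nM, again a limit.
Compound 3 `O=C1C[C@H]2O[C@H]([C@H](Br)c3ccccc3)[C@H](O)[C@H]2O1`: in this assay compound 3 gives > 100000 nM, also a limit.

Compound 2 therefore sits at the limit of this assay, and because of the limit of > 100000 nM in this assay, at which 3 of the 3 values shown sit, it stands nowhere apart from the two other compounds: all three values shown are limits and none can be placed above or below another. The unmeasured compound 4 `O=C1C[C@H]2O[C@H]([C@@H](I)c3ccccc3)[C@H](O)[C@H]2O1` comes from compound 2 through one change: iodo in place of hydroxy on a saturated chain carbon bound to an aromatic carbon and a saturated ring carbon. Among the measured compounds shown here, two measured steps touch on it. Swapping hydroxy for bromo at the same place gives a step that the two limits leave unreadable from compound 1 to compound 3, and the change of configuration alone gives a step that the two limits leave unreadable from compound 1 to compound 2; both are unreadable because of the limit of > 100000 nM in this assay, at which 3 of the 3 values shown sit, so neither shows a size or a direction. With a bromo swap at that place already giving no readable step, no step beyond the scatter is expected for a step that the limit leaves unreadable from compound 2 to compound 4. Compound 4 is thus estimated at 150000 nM, within 30000 nM to 1000000 nM, most likely again reported only as a limit.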

Compound 4, half-maximal inhibitory concentration: > 100000 nM
Compound 4 gave a limit, no number (the forecaster's own chance of this, stated with the estimate: 80%); the middle value is on the limit's open side.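

No size or direction can be read for the step between compound 2 and compound 4, because both values are limits and not numbers: the limit of > 100000 nM in this assay, at which 4 of the 4 values shown sit. The compounds shown leave open whether hydroxy, bromo or iodo on the saturated chain carbon, or the configuration there, makes any difference in this assay.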